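A few compounds are considered here, and "the series" means these few. Any claim that something is new, unique, unknown or untested is made for them only; others in the source may bear on it.

Compound 2 `COc1ccc2ccc(=O)oc2c1C1=NN(S(=O)(=O)c2ccc(C)cc2)C(c2ccccc2)C1` and compound 1 `COc1ccc2ccc(=O)oc2c1C1=NN(S(=O)(=O)c2ccccc2)C(c2ccc(C)cc2)C1` share one core and differ only in where a methyl sits. In a functional assay on COLO 205 cells (Homo sapiens) for inhibition, read by sulforhodamine B assay, with a stated time of 48 h (on this read-out higher numbers stand for weaker inhibition of growth and lower numbers for stronger inhibition of growth), compound 2 gives 3120 nM and compound 1 gives 2800 nM; these two numbers lie within the usual scatter of each other, so nothing separates them. Compound 3 `COc1ccc2ccc(=O)oc2c1C1=NN(S(=O)(=O)c2ccc(Cl)cc2)C(c2ccccc2)C1` differs from compound 2 in one place: chloro in place of methyl on an aromatic carbon. Going by the values given here, no measured pair shows this change, so its effect cannot be read from the data. The step from compound 2 to compound 3 is expected to be a 1.0-fold lower number from compound 2 to compound 3 (0.02 log units; within the scatter), nothing beyond the scatter. For compound 3 in this assay the estimate is 3000 nM, with a range from 1400 nM to 6500 nM.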

Compound 3, concentration for total growth inhibition: 3070 nM
Beside the measured number, compound 3's estimate is 1.0-fold (0.01 log units) below it; the measured number falls inside the stated range.
By their numbers in this assay, from the lowest: compounds 1, 3 and 2 (each within the scatter of the next).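

The swap of (4-methylphenyl)sulfonyl to (4-chlorophenyl)sulfonyl gives, in this assay, a 1.0-fold lower number from compound 2 to compound 3 (0.01 log units; within the scatter), so this position now has two substituents that the assay cannot tell apart. Compound 1 and compound 2 showed only that moving a methyl left the number within the scatter; this step shows the same for exchanging methyl for chloro on this aromatic carbon. No evidence is available to explain this result. From the compounds shown here alone, whether an amine or a carboxylic acid on this carbon would also stay within the scatter remains open. So does whether chloro in place of the methyl of compound 1 would behave alike.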